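Exchanging the Side Chain of Compound 3

A few compounds are considered here, and "the series" means these few. Any claim that something is new, unique, unknown or untested is made for them only; others in the source may bear on it.

Three compounds sharing one core have numbers in a functional assay on HL-60 cells (Homo sapiens) for antiproliferative activity, read by MTT assay, with a stated time of 48 h (on this read-out lower numbers stand for stronger inhibition and higher numbers for weaker inhibition), so far. Compound 1 `NC(=O)CC[C@H](NC(=O)c1cc2ccccc2cn1)C(=O)OCc1ccccc1` gives 44.5 nM as its value, compound 2 `O=C(CNC(=O)c1cc2ccccc2cn1)OCc1ccccc1` gives 57.4 nM as its value, and compound 3 `O=C(C[C@H](NC(=O)c1cc2ccccc2cn1)C(=O)OCc1ccccc1)OCc1ccccc1` gives 74 nM as its value. Compound 3 cannot be separated from the other two, since the data show a 1.3-fold higher number from compound 2 to compound 3 (0.11 log units; within the scatter) and also a 1.7-fold higher number from compound 1 to compound 3 (0.22 log units; within the scatter) as its steps.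

Compound 4 `NCCCC[C@H](NC(=O)c1cc2ccccc2cn1)C(=O)OCc1ccccc1` has not yet been measured. Its difference from compound 3 is 3-aminopropyl in place of benzyloxycarbonyl on a saturated chain carbon, two bonds along the chain from an amide-type nitrogen and a carbonyl carbon and in words it is 3-aminopropyl in place of benzyloxycarbonyl on a saturated chain carbon, two bonds along the chain from an amide-type nitrogen and a carbonyl carbon.

The step at this same place, where benzyloxycarbonyl stands in place of carbamoylmethyl, is a 1.7-fold higher number from compound 1 to compound 3 (0.22 log units; within the scatter) and it bears most directly on the change. The step of a 1.3-fold higher number from compound 1 to compound 2 (0.11 log units; within the scatter) adds that hydrogen in place of 2-carbamoylethyl also left the number within the scatter. Within the data shown here, no measured compound carries 4-aminobutyl, so the range must stay wide.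

The expected change is a 1.2-fold lower number from compound 3 to compound 4 (0.09 log units; within the scatter) and no step beyond the scatter is anticipated. For compound 4 the estimate is 60 nM with an expected range from 20 nM to 180 nM in this assay.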

Compound 4, half-maximal inhibitory concentration: 68.2 nM
Compound 4: middle estimate off by 1.1-fold (0.06 log units), on the low side; measured number inside the range.
By their numbers in this assay, from the lowest: compounds 1, 2, 4 and 3 (each within the scatter of the next).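

Among these compounds, the side chain at this place on the saturated chain carbon tolerates far more than the earlier compounds showed. In this assay, 3-aminopropyl replaces benzyloxycarbonyl with a 1.1-fold lower number from compound 3 to compound 4 (0.04 log units; within the scatter), so the six-membered aromatic ring and the ester can both leave, and a nitrogen can enter, without the number moving beyond the scatter. The comparisons with the smallest and the amide-bearing side chains read the same way, with a 1.2-fold higher number from compound 2 to compound 4 (0.07 log units; within the scatter) and a 1.5-fold higher number from compound 1 to compound 4 (0.19 log units; within the scatter), so hydrogen, 2-carbamoylethyl, (benzyloxycarbonyl)methyl and 4-aminobutyl cannot be told apart in this read-out, and no measurement is available that would account for this.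

Going by these compounds, whether any group at this place can move the number beyond the scatter remains open, for example a free carboxylic acid, a chain longer than 4-aminobutyl, or a guanidine at the end of such a chain. Also open, on these data alone, is what happens when the benzyl ester that all four compounds share gives way to a carboxylic acid, a question these side-chain exchanges do not touch.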